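The compounds below may be only part of what the source reports. "The series", "measured", "known", "first", "only" and "open" are said of these compounds alone.

Compound 1 `CCCC[C@H](NC(=O)[C@H](CCCCN)NC(=O)[C@H](CCCNC(=N)N)NC(=O)c1ccc(/C=C/C(N)=O)cc1)C(N)=O` and compound 2 `CCCC[C@H](NC(=O)[C@H](CCCCN)NC(=O)[C@H](CCCNC(=N)N)NC(=O)c1ccc(/C=C2\SC(=O)N(CCCC)C2=O)cc1)C(N)=O` share a core and differ only in the group hanging from the aromatic ring. In an ADME assay for permeability, using PAMPA (a lower number here means that the compound crosses the layer more slowly, a higher number that the compound crosses the layer faster), compound 1 is recorded as "impermeable" (no number reported). In this assay, going by the values given here, compound 2 gives 1.18 10^-6 cm/s, the only number reported, with compound 1 standing beside it without a single value. Compound 3 `CCCC[C@H](NC(=O)[C@H](CCCCN)NC(=O)[C@H](CCCNC(=N)N)NC(=O)c1ccc(/C=C2\SC(=O)N(Cc3ccc(F)cc3)C2=O)cc1)C(N)=O` keeps everything of compound 2 except for (4-fluorophenyl in place of propyl on a saturated chain carbon bound to an amide-type nitrogen in a ring). Among the compounds with values here, no measured step of this kind is known, so the step from compound 2 to compound 3 in this assay is expected to be small, a 1.3-fold higher number from compound 2 to compound 3 (0.10 log units; within the scatter), perhaps not beyond the scatter. For compound 3 the estimate is 1.5 10^-6 cm/s, between 0.6 10^-6 cm/s and 3.5 10^-6 cm/s.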

Compound 3, apparent permeability: 0.43 10^-6 cm/s
Beside the measured number, compound 3's estimate is 3.5-fold (0.54 log units) above it, outside the stated range (below it).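

In this assay the place on a saturated chain carbon bound to an amide-type nitrogen in a ring proves sensitive to its group: 4-fluorophenyl in place of propyl brings a 2.7-fold lower number from compound 2 to compound 3 (0.44 log units; beyond the scatter) for this single change. The entering group adds one six-membered aromatic ring of carbon but no hydrogen-bond donors or acceptors, and the number still moves. Nothing available explains this step. Open, on these data alone, is how a plain benzyl would read here, which would separate the ring from its fluorine. Also open, as far as these compounds go, is how a longer chain, or a chain ending in an amine, would compare with butyl.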